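Swapping methoxy for methylsulfanyl: one change tested twice

A few compounds are considered here, and "the series" means these few. Any claim that something is new, unique, unknown or untested is made for them only; others in the source may bear on it.

Measured so far:
compound 1, `CSc1ccc(CNc2nc(SC)nc3ncccc23)cc1`: 4320 nM in a functional assay on HT-29 cells (Homo sapiens) for cytotoxicity, read by MTT assay, with a stated time of 72 h; a higher number here means a weaker inhibitor of growth, a lower number a stronger inhibitor of growth
compound 2, `COc1ccc(CNc2nc(SC)nc3ncccc23)cc1`: > 100000 nM, which is a limit of the assay and not a number
compound 3, `COc1ccc(CNc2nc(SC)nc3ccccc23)cc1`: 70200 nM

The change methylsulfanyl in place of methoxy on an aromatic carbon gives an at least 23-fold lower number from compound 2 to compound 1 (1.36 log units; beyond the scatter). Compound 2 sits at the limit of > 100000 nM in this assay, at which 1 of the 3 values shown sits. Compound 3 carries the same methoxy group on another core; the difference between the cores of compound 2 and compound 3 is not broken down here, and compound 3 gives a number where compound 2 gives only a limit. Compound 4, `CSc1ccc(CNc2nc(SC)nc3ccccc23)cc1`, is compound 3 with the same change made once more, (methylsulfanyl in place of methoxy on an aromatic carbon). The step from compound 3 to compound 4 is expected to be of a similar size, a 23-fold lower number from compound 3 to compound 4 (1.37 log units; beyond the scatter). Among the measured compounds shown here, that expectation rests on the single measured example of this change, an at least 23-fold lower number from compound 2 to compound 1 (1.36 log units; beyond the scatter). Compound 4 is therefore estimated at 3000 nM, most likely between 700 nM and 15000 nM in this assay.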

Compound 4, concentration for 50% growth inhibition: 34700 nM
Beside the measured number, compound 4's estimate is 12-fold (1.06 log units) below it; measured number above the stated range.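

In this assay the swap of methoxy for methylsulfanyl again lowers the number, but here the change is only a 2.0-fold lower number from compound 3 to compound 4 (0.31 log units; beyond the scatter). The size of the step therefore does not carry over from one core to the other: the same change on two cores in this assay, an at least 23-fold lower number (1.36 log units; beyond the scatter) from compound 2 to compound 1 and a 2.0-fold lower number (0.31 log units; beyond the scatter) from compound 3 to compound 4, at least 11-fold (1.05 log units) apart, beyond the scatter of two such steps.
Compound 2 gives > 100000 nM, which is a limit and not a number, and these two pairs show neither why the steps differ nor what the change would do on a third core.

Still open, from the compounds shown here alone, is whether another group on that aromatic carbon, such as an amine or an ethoxy group, would give a lower number on either core.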